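A few compounds are considered here, and "the series" means these few. Any claim that something is new, unique, unknown or untested is made for them only; others in the source may bear on it.

Working notes on the series. Among the compounds with values here, in a functional assay on WIL2-NS cells (Homo sapiens) for cytotoxicity, read by MTT assay, with a stated time of 96 h (on this read-out lower numbers stand for an effect already at smaller amounts and higher numbers for an effect only at larger amounts of compound), compound 1 `CC(=O)/C(=C/c1c(-c2ccccc2)[nH]c2ccccc12)C(=O)c1ccccc1` gives 12000 nM, the highest of the three numbers so far. Compound 2 `N#C/C(=C\c1c(-c2ccccc2)[nH]c2ccccc12)C(=O)c1cccs1` gives 6400 nM in this assay, a gap to compound 1 that stays within the scatter. Compound 3 `COc1ccc2[nH]c(-c3ccccc3)c(/C=C(\C#N)S(=O)(=O)c3ccccc3)c2c1` gives 2800 nM in this assay, a gap to compound 1 that lies beyond the scatter. Compound 4 `CCOC(=O)/C(=C/c1c(-c2ccccc2)[nH]c2ccccc12)C(=O)c1ccccc1` differs from compound 1 by ethoxy in place of methyl on a carbonyl carbon. Within the data shown here, no measured pair shows this change, so no step size can be read from the data. The step from compound 1 to compound 4 is expected to be small, a 1.2-fold lower number from compound 1 to compound 4 (0.08 log units; within the scatter), with no direction beyond the scatter. In this assay compound 4 is estimated at 10000 nM, within 4000 nM to 30000 nM.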

Compound 4, half-maximal effective concentration: 12000 nM
The estimate for compound 4 lay 1.2-fold (0.08 log units) below the measured number; low and high end bracket the measured number.
By their numbers in this assay, from the lowest: compound 3; then compounds 2, 1 and 4 (each within the scatter of the next).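

In this assay, ethoxy in place of methyl on a carbonyl carbon gives no change at the digits printed from compound 1 to compound 4 (within the scatter). Within the data shown here, this is the first step that can be read, and it shows that going from acetyl to ethoxycarbonyl, with the added hydrogen-bond acceptor, leaves the number in place at this position. No measurement at hand speaks to the reason for this result. Going by these compounds, whether an amine or a carboxylic acid at this carbonyl carbon would also leave the number in place stays open. Steps involving compound 2 and compound 3 cannot be read, as each differs from the others in more than one place.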